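From a Bis(2-hydroxyethyl)urea to a Methyl Carbamate

The source may hold more compounds than are shown below. What is called first, only, known or untested is meant among the compounds shown, and "the series" means these compounds.

Three compounds share a core and differ only in the group that hangs from a carbonyl carbon on the side chain. Compound 1 `COc1cc(NC(C)CCCNC(=O)NCCCO)c2ncccc2c1` carries a (3-hydroxypropyl)amino group there, and in a functional assay on NCI-H460 cells (Homo sapiens) (a higher number here means a weaker inhibitor, a lower number a stronger inhibitor), compound 1 gives only a limit, > 100000 nM. Compound 2 `COc1cc(NC(C)CCCNC(=O)NOCc2ccccc2)c2ncccc2c1` carries a (benzyloxy)amino group instead, and in this assay compound 2 gives 21000 nM. Compound 3 `COc1cc(NC(C)CCCNC(=O)N(CCO)CCO)c2ncccc2c1` carries a bis(2-hydroxyethyl)amino group, and in this assay compound 3 likewise gives only a limit, > 100000 nM. So compound 3 sits at the same limit as compound 1; that limit is the one noted as the limit of > 100000 nM in this assay, at which 2 of the 3 values shown sit. Among the measured compounds shown here, the step of an at least 4.7-fold higher number from compound 2 to compound 3 (0.67 log units; beyond the scatter) is the only readable step that reaches compound 3, and the step that the two limits leave unreadable from compound 1 to compound 3 cannot be read, while an at least 4.7-fold lower number from compound 1 to compound 2 (0.67 log units; beyond the scatter) runs the opposite way.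

Compound 4 `COC(=O)NCCCC(C)Nc1cc(OC)cc2cccnc12` makes the change (methoxy in place of bis(2-hydroxyethyl)amino on a carbonyl carbon). The two groups that carry hydroxyls both sit at the limit, and the one without hydroxyls, in compound 2, gives a number. The step from compound 3 to compound 4 is therefore expected to move downward, though the limit hides its size. What is expected here is an at least 2.0-fold lower number from compound 3 to compound 4 (0.30 log units; that floor lies within the scatter). Compound 4 is expected to give about 50000 nM, within 10000 nM to 150000 nM.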

Compound 4, half-maximal inhibitory concentration: > 100000 nM
Compound 4: no number, only a limit (the forecaster's own chance of this, stated with the estimate: 45%); at least 2.0-fold (0.30 log units) between middle value and limit.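

In this assay compound 4 gives only a limit, > 100000 nM. Its methoxy group has no hydroxyl, yet it stays at the limit just as the hydroxyl-bearing groups do, so the lack of a hydroxyl on this carbonyl carbon is not enough to give a number, and among the groups shown only the (benzyloxy)amino group of compound 2 does. The one readable step is an at least 4.7-fold higher number from compound 2 to compound 4 (0.67 log units; beyond the scatter), while the steps from compound 1 and from compound 3 to compound 4 cannot be read, with both ends of each resting on the same limit: the limit of > 100000 nM in this assay, at which 3 of the 4 values shown sit.

The compounds shown leave open which part of the (benzyloxy)amino group goes with the number for compound 2, and a benzylamino group or a benzyloxy group on the same carbonyl carbon would help to separate the ring-bearing part from the oxygen on the nitrogen. As far as these compounds go, how far compound 1, compound 3 and compound 4 lie from one another also stays unknown, as does what a longer chain ending in a phenyl ring would give here.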